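This account rests on a few compounds, and the source may have more. Where it says the series, first, only, none or still open, it means among the compounds named here.

In a functional assay on MCF7 cells (Homo sapiens) for antiproliferative activity, read by sulforhodamine B assay, with a stated time of 72 h (on this read-out higher numbers stand for weaker inhibition and lower numbers for stronger inhibition), compound 1 (`O=C(Cn1nc(-c2ccccc2)c2ccccc2c1=O)Nc1cccc(Cl)c1`) gives 74000 nM and compound 2 (`O=C(Cn1nc(Cc2ccccc2)c2ccccc2c1=O)Nc1ccc(F)cc1`) gives 30000 nM on the same read-out. Compound 3 (`O=C(Cn1nc(Cc2ccccc2)c2ccccc2c1=O)Nc1ccccc1Cl`) stands at 89000 nM with the highest number of the set, within the scatter of compound 1 and beyond the scatter of compound 2. Compound 4 (`O=C(Cn1nc(Cc2ccccc2)c2ccccc2c1=O)Nc1cccc(Cl)c1`) differs from it by one change (3-chlorophenyl in place of 2-chlorophenyl on an amide-type nitrogen), with 3-chlorophenyl in place of 2-chlorophenyl on an amide-type nitrogen. Within the data shown here, the only measured step at that nitrogen (a 3.0-fold higher number from compound 2 to compound 3 (0.47 log units; beyond the scatter)) is modest and also exchanges the halogen, so it bears only loosely on this change. Compound 1 carries the same 3-chlorophenyl on a different core and gives 74000 nM in this range. A small move towards a lower number is expected in this assay (a 1.5-fold lower number from compound 3 to compound 4 (0.17 log units; within the scatter)), within the scatter. For compound 4 the estimated value is 60000 nM (expected range 28000 nM to 120000 nM).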

Compound 4, half-maximal inhibitory concentration: 10800 nM
The estimate for compound 4 lay 5.6-fold (0.74 log units) above the measured number; the measured number lies below the stated range.
By their numbers in this assay, from the lowest: compound 4; then compound 2; then compounds 1 and 3 (each within the scatter of the next).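

In this assay the place of the chlorine alone matters at the amide-type nitrogen, with the atoms unchanged: an 8.2-fold lower number from compound 3 to compound 4 (0.92 log units; beyond the scatter). 3-Chlorophenyl also outdoes 4-fluorophenyl there, with a 2.8-fold lower number from compound 2 to compound 4 (0.44 log units; beyond the scatter). With 3-chlorophenyl held, the other site matters as well, since benzyl in place of phenyl on the aromatic carbon gives a 6.9-fold lower number from compound 1 to compound 4 (0.84 log units; beyond the scatter).

Nothing available explains these steps. Still open, going by these compounds, is whether bromine or methoxy in place of this chlorine, or a longer chain in place of benzyl, would hold the lower number.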